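This account rests on a few compounds, and the source may have more. Where it says the series, first, only, none or still open, it means among the compounds named here.

The measured compounds:
Compound 1, `CC(C)(C)[C@@H](O)C(=O)N1C[C@@H]2C[C@@H]2[C@H]1C(=O)NCc1cc(Cl)ccc1-n1cnnn1`, in a functional assay on a cell-free system (plasma, Homo sapiens), with a stated time of 3 min (on this read-out higher numbers stand for weaker inhibition and lower numbers for stronger inhibition), gives 570 nM.
Compound 2, `CC(C)(C)C[C@@H](O)C(=O)N1N=CC[C@H]1C(=O)NCc1cc(Cl)ccc1-n1cnnn1`, gives 590 nM.
Compound 3, `O=C(NCc1cc(Cl)ccc1-n1cnnn1)[C@@H]1CC=NN1C(=O)[C@H](O)Cc1ccccc1`, gives 1400 nM.

Compound 1 and compound 2 are built on different cores; the difference between the two cores is not broken down here. Their two numbers lie within the scatter of each other, so nothing separates them on this read-out. Compound 2 and compound 3 differ in a single place: phenyl in place of tert-butyl on a saturated chain carbon, two bonds along the chain from a carbonyl carbon and an oxygen on a saturated carbon. That change gave a 2.4-fold higher number from compound 2 to compound 3 (0.38 log units; beyond the scatter).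

Compound 4, `O=C(NCc1cc(Cl)ccc1-n1cnnn1)[C@@H]1[C@H]2C[C@H]2CN1C(=O)[C@H](O)c1ccccc1`, has not yet been measured. It stands to compound 1 as compound 3 stands to compound 2, through (phenyl in place of tert-butyl on a saturated chain carbon bound to a carbonyl carbon and an oxygen on a saturated carbon). The two changes are the same kind of change but not the same: going from compound 2 to compound 3 the carbon that carries the group is two bonds along the chain from a carbonyl carbon and an oxygen on a saturated carbon, whereas going from compound 1 to compound 4 that carbon is bound directly to a carbonyl carbon and an oxygen on a saturated carbon, and the two cores differ as well. Among the compounds with values here, with one measured instance as the only guide, compound 4 is expected to give a 2.5-fold higher number from compound 1 to compound 4 (0.39 log units; beyond the scatter), because a 2.4-fold higher number from compound 2 to compound 3 (0.38 log units; beyond the scatter) is what the same kind of change produced. The estimate for compound 4 is therefore 1400 nM, between 650 nM and 3200 nM. The range is kept wide: the place of the change and the core both differ from the measured pair.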

Compound 4, half-maximal inhibitory concentration: 960 nM
Beside the measured number, compound 4's estimate is 1.5-fold (0.16 log units) above it, and the stated range covers the measured number.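

In this assay, putting phenyl in place of tert-butyl on the core of compound 1 gave a 1.7-fold higher number from compound 1 to compound 4 (0.23 log units; within the scatter), so this step alone does not separate the two compounds. Set beside the step on the other core, it points the same way on the printed numbers, and the two steps cannot be told apart: the same change on two cores in this assay, a 2.4-fold higher number (0.38 log units; beyond the scatter) from compound 2 to compound 3 and a 1.7-fold higher number (0.23 log units; within the scatter) from compound 1 to compound 4, 1.4-fold (0.15 log units) apart, within the scatter of two such steps. Within the data shown here, this shows that the change reads alike on these two cores, but it rests on only two pairs, in which the carbon carrying the group differs as well as the core, so it neither establishes a general rule for carrying the change to other cores nor shows that phenyl gives weaker inhibition than tert-butyl on the core of compound 1.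

The compounds shown leave open whether the two cores would still read alike with the group on the same carbon in both, that is, on a saturated chain carbon bound to a carbonyl carbon and an oxygen on a saturated carbon. They also leave open how other groups in that place, such as an amine, a carboxylic acid or a longer chain, would read on either core.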